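Notes on the amine substituent across three analogues

This account rests on a few compounds, and the source may have more. Where it says the series, first, only, none or still open, it means among the compounds named here.

Compound 1 `CCCCOc1ccc(-c2nc3ncccn3c2NCCC)cc1` gives a limit of the assay in a toxicity assay on A549 cells (Homo sapiens) for cytotoxicity, read by luminescence and CellTiter-Glo, with a stated time of 48 h (on this read-out higher numbers stand for lower toxicity in this test and lower numbers for higher toxicity in this test), not a number: compound 1 reads > 100000 nM.
Compound 2 `CCCCOc1ccc(-c2nc3ncccn3c2Nc2ccccc2)cc1` reads 100000 nM in this assay.
Compound 3 `CCCCOc1ccc(-c2nc3ncccn3c2NCc2ccccn2)cc1` is not yet measured in this assay.

Among the measured compounds shown here, compound 2 is the only compound of the pair with a number in this assay; the other value is a limit, as the limit of > 100000 nM in this assay, at which 1 of the 2 values shown sits, states. For the measured compounds named here, the one measured step, a number no higher from compound 1 to compound 2 (the limit leaves the size open), has no readable size because one end is a limit.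

The change to compound 3 is (pyridin-2-yl)methyl in place of phenyl on a nitrogen on an aromatic ring. Going by the values given here, no measured step bears on this change directly; the step from propyl to phenyl gave no readable size. With nothing to set a direction, compound 3 is expected to stay within scatter of compound 2, an estimated step of no change at the digits printed from compound 2 to compound 3 (within the scatter). Compound 3 is therefore estimated at 100000 nM, with a range from 50000 nM to 200000 nM, and a fair chance the assay again reports only a limit.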

Compound 3, half-maximal cytotoxic concentration: > 100000 nM
Compound 3: a limit, no number (the forecaster's own chance of this, stated with the estimate: 50%); the middle value sits exactly at the limit.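

Compound 3 gives > 100000 nM in this assay, a limit of the assay and not a number. So a ring with 1 hetero atom, set on a carbon spacer as (pyridin-2-yl)methyl, brings no measurable toxicity on this nitrogen, and the step reads as a number no lower from compound 2 to compound 3 (the limit leaves the size open); this and the other steps among the three compounds cannot be read for size. Propyl and (pyridin-2-yl)methyl on this nitrogen now end at the same limit: the limit of > 100000 nM in this assay, at which 2 of the 3 values shown sit.

As far as these compounds go, whether any group at this place gives a number clearly apart from compound 2, at 100000 nM, stays open. A cyclohexyl or a longer chain on this nitrogen would test that.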